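The compounds below may be only part of what the source reports. "The series", "measured", "known", "first", "only" and "open" are said of these compounds alone.

Three close relatives of one dihydropyridine core have been measured. Compound 1 `C=C(C)CCOC(=O)C1=C(C)NC(C)=C(C(=O)OC)C1c1cccc([N+](=O)[O-])c1` gives 47 nM in a functional assay on HEK293 cells for antagonist activity at Voltage-dependent L-type calcium channel subunit alpha-1D (Rattus norvegicus), read by FLIPR; a higher number here means a weaker inhibitor, a lower number a stronger inhibitor. Compound 2 `COC(=O)C1=C(C)NC(C)=C(C(=O)OCC(C)[N+](=O)[O-])C1c1cccc([N+](=O)[O-])c1` gives 111 nM, and compound 3 `COC(=O)C1=C(C)NC(C)=C(C(=O)OCc2cc([N+](=O)[O-])cc([N+](=O)[O-])c2)C1c1cccc([N+](=O)[O-])c1` gives 40 nM. Compound 3 thus carries the lowest of the three numbers, though one of its gaps (a 1.2-fold lower number from compound 1 to compound 3 (0.07 log units; within the scatter)) is within the scatter, while the other (a 2.8-fold lower number from compound 2 to compound 3 (0.44 log units; beyond the scatter)) is modest and beyond it.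

Compound 4 `COC(=O)C1=C(C)NC(C)=C(C(=O)OCc2ccc(OC)c(OC)c2)C1c1cccc([N+](=O)[O-])c1` differs from compound 3 only at the ester group: 3,4-dimethoxyphenyl in place of 3,5-dinitrophenyl on a saturated chain carbon bound to an oxygen next to a carbonyl group. Both steps that end at compound 3 bear on this change, since each swaps the group on the same carbon; one was within the scatter and the other modest. Among the measured compounds shown here, no measured step involves a dimethoxyphenyl group, so the expectation rests on how little this position has moved the number so far. For compound 4 the expected outcome in this assay is a small shift toward a higher number, a 1.6-fold higher number from compound 3 to compound 4 (0.21 log units; within the scatter), with the estimate 65 nM and a range from 25 nM to 170 nM.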

Compound 4, half-maximal inhibitory concentration: 117 nM
For compound 4 the middle estimate is 1.8-fold (0.26 log units) below the measured one; the measured number falls inside the stated range.
By their numbers in this assay, from the lowest: compounds 3 and 1 (each within the scatter of the next); then compounds 2 and 4 (each within the scatter of the next).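

In this assay, replacing 3,5-dinitrophenyl with 3,4-dimethoxyphenyl gives a 2.9-fold higher number from compound 3 to compound 4 (0.47 log units; beyond the scatter) and so shows that having a benzene ring on this carbon does not settle the number: what the ring carries matters. Replacing 1-nitroethyl with the same new group gives a 1.1-fold higher number from compound 2 to compound 4 (0.02 log units; within the scatter) while replacing 2-methylprop-2-en-1-yl with it gives a 2.5-fold higher number from compound 1 to compound 4 (0.40 log units; beyond the scatter) and so the two ring-bearing esters no longer fall together, with compound 4 level with the non-ring compound 2 instead. No measurement here explains the gap between the two rings.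

The two rings differ in both the kind of substituent and where it sits, so these effects cannot be separated. A plain phenyl ring, or 3,5-dimethoxyphenyl, would help to pull them apart.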